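Working notes: the step from methoxy to ethoxy

The compounds below may be only part of what the source reports. "The series", "measured", "known", "first", "only" and "open" are said of these compounds alone.

Measured in a functional assay on FM3A cells (Mus musculus) for antiproliferative activity, with a stated time of 48 h; on this read-out higher numbers stand for weaker inhibition and lower numbers for stronger inhibition:
- compound 1 `C=C(Br)C(=O)Nc1ccc(/C=C/C(=O)c2ccc(Cl)cc2)cc1`: 1300 nM
- compound 2 `C=C(Br)C(=O)Nc1ccc(/C=C/C(=O)c2ccc(OC)cc2)cc1`: 1200 nM

Compound 2 stands at 1200 nM and compound 1 at 1300 nM, so the two cannot be told apart on these numbers. Among the compounds with values here, the one measured step, a 1.1-fold lower number from compound 1 to compound 2 (0.03 log units; within the scatter), lies within the scatter and places methoxy where chloro stood on an aromatic carbon.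

Next in line is compound 3 `C=C(Br)C(=O)Nc1ccc(/C=C/C(=O)c2ccc(OCC)cc2)cc1`, which keeps the shared core and carries ethoxy in place of methoxy. The difference is methyl in place of hydrogen on a saturated chain carbon bound to an oxygen on an aromatic ring.

Within the data shown here, no measured pair shows this exact change, so the evidence is indirect and thin. It rests on compound 2 alone, where the exchange a 1.1-fold lower number from compound 1 to compound 2 (0.03 log units; within the scatter) left this assay within the scatter. On that basis no shift beyond the scatter is expected, and the estimated step is no change at the digits printed from compound 2 to compound 3 (within the scatter). For compound 3 the expected value is 1200 nM, with an estimated range of 650 nM to 2200 nM.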

Compound 3, half-maximal inhibitory concentration: 680 nM
Compound 3: middle estimate off by 1.8-fold (0.25 log units), on the high side, and the stated range covers the measured number.
By their numbers in this assay, from the lowest: compounds 3, 2 and 1 (each within the scatter of the next).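

Working notes, continued. In this assay, within the data shown here, the change from methoxy to ethoxy, methyl in place of hydrogen on a saturated chain carbon bound to an oxygen on an aromatic ring, gives a 1.8-fold lower number from compound 2 to compound 3 (0.25 log units; within the scatter) and so supplies the first direct reading of this position, a reading that does not separate the two compounds. Replacing chloro with ethoxy gives a 1.9-fold lower number from compound 1 to compound 3 (0.28 log units; within the scatter) as well, so on these numbers chloro, methoxy and ethoxy cannot be told apart in this series. No measurement on hand offers an explanation for these numbers or connects them to any property of the groups.

From the compounds shown here alone, whether a longer chain such as propoxy or butoxy, or an amine or a carboxylic acid in place of ethoxy on that aromatic carbon, would move the number beyond the scatter stays open. All three compounds share the same core, so the compounds shown say nothing about how this read-out responds to changes elsewhere on it.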